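Trimming an Oxolane Amide to a Methyl Carbamate

The source may hold more compounds than are shown below. What is called first, only, known or untested is meant among the compounds shown, and "the series" means these compounds.

Compound 1 `Cc1cc(C(N)=O)nn1Cc1cc(Cl)ccc1OCc1ccccc1` gives 3.7 in a physicochemical assay for lipophilicity, at pH 7.4; on this read-out higher numbers stand for higher lipophilicity and lower numbers for lower lipophilicity. Compound 2 `Cc1cc(C(=O)Nc2ccc(F)cc2)nn1Cc1cc(Cl)ccc1OCc1ccccc1` gives 3. Compound 3 `Cc1cc(NC(=O)C2CCOC2)nn1Cc1cc(Cl)ccc1OCc1ccccc1` gives > 3.7.

The value for compound 3 is a limit of the assay and not a number: compound 3 sits at the limit of > 3.7 in this assay, at which 1 of the 3 values shown sits. Compound 4 `COC(=O)Nc1cc(C)n(Cc2cc(Cl)ccc2OCc2ccccc2)n1` differs from it in one place, (methoxy in place of oxolan-3-yl on a carbonyl carbon). The measured steps touch other parts of the molecule: a number 0.70 log units lower from compound 1 to compound 2 (beyond the scatter), and a number at least 0.70 log units higher from compound 2 to compound 3 (beyond the scatter). Neither exchanges the group on the carbonyl carbon, so they give no direct guide. The change replaces 5 heavy atoms with 2, and a modest lowering is expected, a number at least 0.20 log units lower from compound 3 to compound 4 (that floor lies within the scatter). Compound 4 is therefore estimated at 3.5, with a range from 2.9 to 4.1.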

Compound 4, distribution coefficient: > 3.7
Compound 4: a limit, no number; the forecaster's own chance of this, stated with the estimate: 30%; at least 0.20 log units between middle value and limit.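

In this assay compound 4 gives > 3.7 as a limit of the assay and not a number. Methoxy in place of oxolan-3-yl on the carbonyl carbon leaves compound 4 at the same limit as compound 3, so the step to compound 4 from compound 3 cannot be read: the limit of > 3.7 in this assay, at which 2 of the 4 values shown sit. Two steps can be read. One is a number at least 0.70 log units higher from compound 2 to compound 4 (beyond the scatter) with (methoxycarbonyl)amino in place of (4-fluorophenyl)carbamoyl on an aromatic carbon. The other is a number no lower from compound 1 to compound 4 (the limit leaves the size open) with (methoxycarbonyl)amino in place of carbamoyl on an aromatic carbon.

As far as these compounds go, how far compound 3 and compound 4 lie past the limit stays open, so the size of this change remains unknown. Also open, from the compounds shown here alone, is whether an ethoxy or a dimethylamino group on that carbonyl carbon would give a value inside the limit.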